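This account rests on a few compounds, and the source may have more. Where it says the series, first, only, none or still open, it means among the compounds named here.

In an ADME assay on CCRF-CEM cells (Homo sapiens) for cytotoxicity (on this read-out lower numbers stand for higher toxicity in this test and higher numbers for lower toxicity in this test), three compounds have been measured so far. Compound 1 `Nc1ccn([C@H]2C[C@H](SS[C@H]3C[C@H](n4ccc(N)nc4=O)O[C@@H]3CO)[C@@H](CO)O2)c(=O)n1` gives 216000 nM. Compound 3 `Cc1cn([C@H]2C[C@H](SSc3ccc([N+](=O)[O-])cc3)[C@@H](CO)O2)c(=O)[nH]c1=O` gives 23000 nM. For compound 2 `O=c1nc(O)ccn1[C@H]1C[C@H](SS[C@H]2C[C@H](n3ccc(O)nc3=O)O[C@@H]2CO)[C@@H](CO)O1` the assay reports only a limit and no number: >= 250000 nM, which is the limit of >= 250000 nM in this assay, at which 1 of the 3 values shown sits. Of the two actual numbers, compound 3 has the lower one, which here means the stronger cytotoxicity, and the gap to compound 1 lies beyond the usual scatter of this kind of measurement.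

Compound 4 `CCCCCCSS[C@H]1C[C@H](n2cc(C)c(=O)[nH]c2=O)O[C@@H]1CO` has not yet been measured. It differs from compound 3 in one place: hexyl in place of 4-nitrophenyl on a sulfur. For the measured compounds named here, no pair of measured compounds shows a change of this kind, so its effect in this assay can only be guessed from compound 3 itself. A modest move towards a higher number, meaning somewhat weaker toxicity, seems most likely, though a shift of that size could well stay within the scatter, and a move in the other direction cannot be ruled out. Compound 4 is expected to give about 40000 nM, within a range from 8000 nM to 200000 nM. This amounts to an expected step of a 1.7-fold higher number from compound 3 to compound 4 (0.24 log units; within the scatter).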

Compound 4, half-maximal cytotoxic concentration: 39000 nM
Estimate against measurement, compound 4: 1.0-fold (0.01 log units) above; measured number inside the range.
By their numbers in this assay, from the lowest: compounds 3 and 4 (each within the scatter of the next); then compound 1. At a limit, above all of these: compound 2.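

In this assay, putting hexyl in place of 4-nitrophenyl on a sulfur whose other neighbours are sulfur gives a 1.7-fold higher number from compound 3 to compound 4 (0.23 log units; within the scatter) and so leaves the read-out within the usual scatter. At this place, then, a group with one six-membered aromatic ring of carbon and a chain with no ring at all read alike, even though the chain brings none of the nitrogen or oxygen atoms of 4-nitrophenyl. In this one pair, neither the ring nor those atoms turn out to be needed for toxicity of this size, which compound 3 alone could not show, and nothing measured here explains why the two groups read alike.

From the compounds shown here alone, whether this tolerance extends to other groups on the same sulfur remains open: a shorter chain such as butyl, a longer chain such as decyl, or a hexyl chain ending in an amine or a carboxylic acid could each read differently. Going by these compounds, it is also open whether the same change would read alike with the rest of the molecule altered elsewhere.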